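The compounds below may be only part of what the source reports. "The series", "measured", "known", "first", "only" and "open" are said of these compounds alone.

Compound 1 `CC(C)[C@H]1CC[C@@]2(CO2)[C@H]2C(=O)OCC(C(=O)OCc3ccc(-c4ccc([N+](=O)[O-])cc4)o3)=C[C@H]12`, compound 3 `CNC(=O)C1=C[C@@H]2[C@@H](C(C)C)CC[C@@]3(CO3)[C@H]2C(=O)OC1` and compound 2 `CC(C)[C@H]1CC[C@@](O)(CO)[C@H]2C(=O)OCC(C(=O)O)=C[C@H]12` are built on the shared core. In a functional assay on NAMALVA cells (Homo sapiens) for inhibition, with a stated time of 72 h (on this read-out lower numbers stand for stronger inhibition and higher numbers for weaker inhibition), compound 1 gives 1190 nM, and compound 3 gives 1280 nM. For compound 2 this assay reports only a limit, > 32000 nM. That is the limit of > 32000 nM in this assay, at which 1 of the 3 values shown sits. Compound 4 `CC(C)[C@H]1CC[C@@](O)(CI)[C@H]2C(=O)OCC(C(=O)O)=C[C@H]12` is compound 2 with one change: iodo in place of hydroxy on a saturated chain carbon bound to a saturated ring carbon. No measured pair of compounds differs in just this way, so the size of the step is not known from the numbers shown. The expected step from compound 2 to compound 4 in this assay is an at least 1.6-fold lower number from compound 2 to compound 4 (0.20 log units; that floor lies within the scatter), at most modest and possibly none beyond the scatter. Compound 4 is estimated at 20000 nM, within a range from 4000 nM to 100000 nM.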

Compound 4, half-maximal inhibitory concentration: 3260 nM
The estimate for compound 4 lay 6.1-fold (0.79 log units) above the measured number, and the stated range ends above it.
By their numbers in this assay, from the lowest: compounds 1 and 3 (each within the scatter of the next); then compound 4. At a limit, above all of these: compound 2.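

Among the compounds shown here, this position is not indifferent to change: in this assay, replacing hydroxy with iodo gives an at least 9.8-fold lower number from compound 2 to compound 4 (0.99 log units; beyond the scatter), the first measured step at this place. The step is a floor and its true size stays unknown, because compound 2 has only a limit in this assay: the limit of > 32000 nM in this assay, at which 1 of the 4 values shown sits.

The compounds shown leave open how an amine, a chloro group or a longer chain would read at this place. They also leave open whether the same change would give a similar step on a compound carrying a different group elsewhere on the shared core.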